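The compounds below may be only part of what the source reports. "The series", "measured", "known", "first", "only" and "open" are said of these compounds alone.

Compound 1 `Cc1ccc(-n2nc(-c3ccc4ccccc4c3)nc2N2C(=O)COC23C=CC(=O)C=C3)cc1` gives 30 nM
Compound 2 `O=C1C=CC2(C=C1)OCC(=O)N2c1nc(-c2ccc3ccccc3c2)nn1-c1ccc2ccccc2c1` gives 50 nM

In a functional assay on MDA-MB-231 cells (Homo sapiens) for antiproliferative activity, with a stated time of 5 days (a higher number here means a weaker inhibitor, a lower number a stronger inhibitor), only these two compounds have been measured, and compound 2 (50 nM) sits level with compound 1 (30 nM), since the gap between them lies within the scatter. Compound 3 `O=C1C=CC2(C=C1)OCC(=O)N2c1nc(-c2ccc3ccccc3c2)nn1-c1ccc(Cl)cc1` is the next to be tested. It keeps the core of compound 2 and changes one group: 4-chlorophenyl in place of naphthalen-2-yl on an aromatic nitrogen. In words, 4-chlorophenyl comes in place of naphthalen-2-yl on an aromatic nitrogen. Among the measured compounds shown here, one measured step bears on this same nitrogen, a 1.7-fold higher number from compound 1 to compound 2 (0.22 log units; within the scatter), where naphthalen-2-yl replaced 4-methylphenyl. That swap between a single ring and a double ring moved this assay by no more than the scatter, so no real shift is expected here either. The expected step is a 1.3-fold lower number from compound 2 to compound 3 (0.10 log units; within the scatter), with no direction beyond the scatter. For compound 3 the estimated value is 40 nM, with an expected range from 15 nM to 110 nM.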

Compound 3, half-maximal inhibitory concentration: 70 nM
Beside the measured number, compound 3's estimate is 1.8-fold (0.24 log units) below it, and the stated range covers the measured number.
By their numbers in this assay, from the lowest: compounds 1, 2 and 3 (each within the scatter of the next, the first and the last beyond it).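

In this assay, 4-chlorophenyl in place of naphthalen-2-yl on this aromatic nitrogen gives a 1.4-fold higher number from compound 2 to compound 3 (0.15 log units; within the scatter), so a single ring serves here as well as a double ring, whether it carries methyl or chloro. The small group on that single ring may still matter, though only slightly: chloro in place of methyl gives a 2.3-fold higher number from compound 1 to compound 3 (0.37 log units; beyond the scatter), a modest step and the only one so far beyond the scatter. No measurement at hand explains the size of this step.

Still open, on these data alone, is whether this nitrogen accepts anything other than an aromatic ring bearing small groups; an amine or a carboxylic acid on the single ring, or a plain alkyl chain on the nitrogen itself, would test that. As far as these compounds go, the naphthalen-2-yl group on the other ring atom also stays the same throughout, so its role remains unknown.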